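This account rests on a few compounds, and the source may have more. Where it says the series, first, only, none or still open, it means among the compounds named here.

For the measured compounds named here, in an ADME assay on MT4 cells (Homo sapiens) for cytotoxicity, read by MTT assay, with a stated time of 4 days (on this read-out higher numbers stand for lower toxicity in this test and lower numbers for higher toxicity in this test), compound 2 `O=C(COc1cccc2ccccc12)N/N=C/c1ccc([N+](=O)[O-])cc1` gives the highest of the three numbers so far (87.9 ug/mL) while compound 1 `O=C(COc1cccc2ccccc12)N/N=C/c1ccc(O)cc1` gives 26.5 ug/mL and compound 3 `C/C(=N\NC(=O)COc1cccc2ccccc12)c1ccc(Cl)cc1` gives 4.07 ug/mL on the same read-out. The change fluoro in place of nitro on an aromatic carbon leads to compound 4 `O=C(COc1cccc2ccccc12)N/N=C/c1ccc(F)cc1` and amounts to fluoro in place of nitro on an aromatic carbon, para to a large group. Going by the values given here, the one measured step that swaps a group at this place is a 3.3-fold higher number from compound 1 to compound 2 (0.52 log units; beyond the scatter) (modest, with nitro in place of hydroxy). Among the compounds with values here, compound 3 carries other changes as well, so it offers no clean step, and no fluoro compound has been measured. Nitro stands on the higher side of that step (a 3.3-fold higher number from compound 1 to compound 2 (0.52 log units; beyond the scatter)) so losing it is expected to bring a modest move to a lower number, though a result within the scatter cannot be excluded. The expected size is a 2.5-fold lower number from compound 2 to compound 4 (0.40 log units; beyond the scatter) as an estimated step. For compound 4 the estimated value is 35 ug/mL with an expected range of 10 ug/mL to 100 ug/mL in these notes.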

Compound 4, half-maximal cytotoxic concentration: 65.1 ug/mL
The estimate for compound 4 lay 1.9-fold (0.27 log units) below the measured number; the measured number falls inside the stated range.
By their numbers in this assay, from the lowest: compound 3; then compound 1; then compounds 4 and 2 (each within the scatter of the next).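

In this assay, the step of a 1.4-fold lower number from compound 2 to compound 4 (0.13 log units; within the scatter) lies within the scatter, so fluoro and nitro cannot be told apart at this place, although nitro has 3 heavy atoms and 2 hydrogen-bond acceptors and fluoro has 1 heavy atom and 0 acceptors. Hydroxy now differs from both groups, with a 2.5-fold higher number from compound 1 to compound 4 (0.39 log units; beyond the scatter) joining a 3.3-fold higher number from compound 1 to compound 2 (0.52 log units; beyond the scatter), so compound 1 gives the lowest number of the three compounds that differ only at this place. No measurement accompanying these compounds accounts for this difference.

On these data alone, whether an amine or a carboxylic acid at this place would match fluoro and nitro or hydroxy remains open. Compound 3 differs from the others in more than one place, so the source of its separate number also remains unresolved.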